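A few compounds are considered here, and "the series" means these few. Any claim that something is new, unique, unknown or untested is made for them only; others in the source may bear on it.

Compound 1 `O=C(Nc1ccccc1)c1cccc(Br)c1O` gives 82000 nM in an ADME assay on HEK293 cells (Homo sapiens) for cytotoxicity, read by reporter gene assay and resazurin assay, with a stated time of 48 h; on this read-out lower numbers stand for higher toxicity in this test and higher numbers for lower toxicity in this test. Compound 2 `O=C(Nc1cccc(Cl)c1)c1cccc(Br)c1` gives 51000 nM in this assay. Compound 3 `COc1c(Br)cccc1C(=O)Nc1cccc(Cl)c1` gives > 100000 nM in this assay, which is a limit of the assay and not a number.

Compound 3 therefore stands at the edge of what this assay reports: the limit of > 100000 nM in this assay, at which 1 of the 3 values shown sits. From compound 3 to compound 4 `O=C(Nc1cccc(Cl)c1)c1cccc(Br)c1O` the change is hydrogen in place of methyl on an oxygen on an aromatic ring. Among the compounds with values here, the one measured step that touches this position, an at least 1.9-fold higher number from compound 2 to compound 3 (0.29 log units; that floor lies within the scatter), concerns methoxy in place of hydrogen and stays within the scatter. Within the data shown here, no measured step covers hydroxy against methoxy directly; compound 1, which carries the hydroxy, and compound 2, which carries hydrogen at that carbon, show values that sit within the scatter of each other. Compound 4 is therefore expected to land near the values of compound 1 and compound 2, and the expected step of an at least 1.2-fold lower number from compound 3 to compound 4 (0.09 log units; that floor lies within the scatter) is not expected to exceed the scatter. Compound 4 is estimated at 80000 nM, within 35000 nM to 180000 nM.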

Compound 4, half-maximal cytotoxic concentration: 32000 nM
Estimate against measurement, compound 4: 2.5-fold (0.40 log units) above; the measured number lies below the stated range.
By their numbers in this assay, from the lowest: compounds 4, 2 and 1 (each within the scatter of the next, the first and the last beyond it). At a limit, above all of these: compound 3.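

In this assay, within the data shown here, removing the methyl from this oxygen is the first change at this position whose step passes the scatter, with an at least 3.1-fold lower number from compound 3 to compound 4 (0.49 log units; beyond the scatter). That figure is only a floor, since compound 3 stands at a limit of the assay and not at a number: the limit of > 100000 nM in this assay, at which 1 of the 4 values shown sits. Hydroxy in place of hydrogen on this aromatic carbon stays within the scatter, with a 1.6-fold lower number from compound 2 to compound 4 (0.20 log units; within the scatter), whereas with the hydroxy held in place, chloro in place of hydrogen on an aromatic carbon gives a 2.6-fold lower number from compound 1 to compound 4 (0.41 log units; beyond the scatter).

The compounds shown leave open how far compound 3 truly lies from compound 4. They also leave open how an amine or a carboxylic acid in place of the hydroxy, or an ethyl in place of the methyl on this oxygen, would read in this assay.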